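The source may hold more compounds than are shown below. What is called first, only, known or untested is meant among the compounds shown, and "the series" means these compounds.

Three compounds have been measured in a functional assay on the whole organism (strain albino) for inhibition, with Rattus norvegicus as the target, read by paw edema, with stated times of 30 min and 4 h, at a dose of 100 mg/kg by the oral route; on this read-out higher numbers stand for more inhibition at the one dose given (going by the name of the read-out) and lower numbers for less inhibition:

compound 1 `COc1ccc(/C=C/C(=O)c2ccc(NC(=O)C(C)Br)cc2)cc1`, 38%
compound 2 `CC(Br)C(=O)Nc1ccc(C(=O)/C=C/c2ccco2)cc1`, 36%
compound 3 `COc1ccc(/C=C/C(=O)c2ccc(NC(=O)COc3ccc(/C(C)=N\O)cc3)cc2)cc1`, 42%

Compound 1 and compound 2 differ in one place: furan-2-yl in place of 4-methoxyphenyl on a double-bonded chain carbon bound to a double-bonded chain carbon. On this change, a number 2 percentage points lower from compound 1 to compound 2 (within the scatter). The core of compound 3 differs from the core of compound 1 by more than one place, and that difference is not broken down here; their two values lie within the scatter of each other, as do the values of compound 3 and compound 2.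

Compound 4 `C/C(=N/O)c1ccc(OCC(=O)Nc2ccc(C(=O)/C=C/c3ccco3)cc2)cc1` has not yet been measured. It differs from compound 3 by furan-2-yl in place of 4-methoxyphenyl on a double-bonded chain carbon bound to a double-bonded chain carbon, the same change as from compound 1 to compound 2, made on the core of compound 3 instead. Because a number 2 percentage points lower from compound 1 to compound 2 (within the scatter), the expected step is a number 2 percentage points lower from compound 3 to compound 4 (within the scatter). Compound 4 is therefore estimated at 40%, between 30% and 50%.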

Compound 4, a percentage reported as inhibition, in the whole organism at one dose (the size of the read-out at that dose, not a potency): 48%
Compound 4: the middle estimate sits 8 percentage points below what was measured, within the range that was stated.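

In this assay, putting furan-2-yl in place of 4-methoxyphenyl gives a step of a number 6 percentage points higher from compound 3 to compound 4 (within the scatter), and the two cores can now be compared: the same change on two cores in this assay, a number 2 percentage points lower (within the scatter) from compound 1 to compound 2 and a number 6 percentage points higher (within the scatter) from compound 3 to compound 4, 8 percentage points apart, within the scatter of two such steps. The change therefore carries from one core to the other with no difference that stands out from the scatter, and on neither core does it clearly shift the inhibition. Two small steps at a single dose do not show that the change has no effect, nor that the same would hold on other cores.

Going by these compounds, it remains open how other groups in this same place would read, such as thiophen-2-yl or a phenyl ring carrying an amine or a carboxylic acid. Whether any of them would give a step beyond the scatter is also unknown.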